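Amino in place of acetoxy on the aromatic ring

The compounds below may be only part of what the source reports. "The series", "measured", "known", "first", "only" and "open" are said of these compounds alone.

Of the compounds shown here, two have been tested in a functional assay on NCI-H460 cells (Homo sapiens) for antiproliferative activity, with a stated time of 72 h; on this read-out lower numbers stand for stronger inhibition and higher numbers for weaker inhibition. Compound 1 `C=CC[C@H]1C[C@]2([C@H](C)Cc3ccc(OC)c(OC)c3)OCOC2=CC1=O` carries two methoxy groups on its aromatic ring and gives 320 nM. Compound 2 `C=CC[C@H]1C[C@]2(C(C)Cc3ccc(OC)c(OC(C)=O)c3)OCOC2=CC1=O` carries a methoxy group and an acetoxy group; in this assay compound 2 gives 110 nM, the lowest of the two numbers, and the gap to compound 1 lies beyond the usual scatter. Going by the values given here, no single-site step between measured compounds is available, so nothing more is drawn from this pair.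

Compound 3 `C=CC[C@H]1C[C@]2(C(C)Cc3ccc(OC)c(N)c3)OCOC2=CC1=O` is derived from compound 2 by the change amino in place of acetoxy on an aromatic carbon: an amino group takes the place of the acetoxy group, on an aromatic carbon of a six-membered aromatic ring of carbon only, ortho to a methoxy group and meta to a large group. Among the compounds with values here, no measured step resembles this exchange, so the direction is open. Compound 3 is expected to stay close to compound 2, with a step of a 1.8-fold higher number from compound 2 to compound 3 (0.26 log units; within the scatter) that need not exceed the scatter. Compound 3 is estimated at 200 nM, within a range from 60 nM to 700 nM.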

Compound 3, half-maximal inhibitory concentration: 180 nM
Compound 3: middle estimate off by 1.1-fold (0.05 log units), on the high side; the measured number falls inside the stated range.
By their numbers in this assay, from the lowest: compounds 2, 3 and 1 (each within the scatter of the next, the first and the last beyond it).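

Replacing the acetoxy group with an amino group gives a 1.6-fold higher number from compound 2 to compound 3 (0.21 log units; within the scatter) in this assay, so this position, ortho to a methoxy group and meta to a large group, accepts the exchange without a step that can be told from the scatter. Going by these compounds alone, this is the first single-site reading at this position, and it shows that four heavy atoms with no hydrogen-bond donor can give way to one nitrogen atom carrying a hydrogen-bond donor while compound 2 and compound 3 remain indistinguishable on this read-out. Nothing measured here explains why the two compounds read alike.

As far as these compounds go, whether a hydroxyl group, an acetamide or a dimethylamino group at the same position would also stay within the scatter of compound 2 remains open, so one exchange does not yet define what this position accepts. Also open, from the compounds shown here alone, is whether the amino group would behave the same way if the neighbouring methoxy group gave way to an ethoxy group or a fluorine atom, or in any assay other than this one on a single cell line.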